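Series notes: replacing the chloromethyl group on the pyridine end

A few compounds are considered here, and "the series" means these few. Any claim that something is new, unique, unknown or untested is made for them only; others in the source may bear on it.

Three compounds of a shared core have been run in an assay for inhibition of Fatty-acid amide hydrolase 1 (Rattus norvegicus), using a Dixon plot, with a stated time of 3 h; a higher number here means a weaker inhibitor, a lower number a stronger inhibitor. Compound 1 `O=Cc1ccc(-c2cnc(C(=O)CCCCCCc3ccccc3)o2)nc1` gives 2 nM; compound 3 `N#C/C=C/c1ccc(-c2cnc(C(=O)CCCCCCc3ccccc3)o2)nc1` gives 2.7 nM; compound 2 `O=C(CCCCCCc1ccccc1)c1ncc(-c2ccc(CCl)cn2)o1` gives 20.1 nM, the highest number of the three. The step of a 1.4-fold higher number from compound 1 to compound 3 (0.13 log units; within the scatter) lies within the scatter, whereas a 10-fold higher number from compound 1 to compound 2 (1.00 log units; beyond the scatter) and a 7.4-fold lower number from compound 2 to compound 3 (0.87 log units; beyond the scatter) both lie beyond it, so the chloromethyl compound stands apart from the other two.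

The next compound, compound 4 `CCOS(=O)(=O)/C=C/c1ccc(-c2cnc(C(=O)CCCCCCc3ccccc3)o2)nc1`, differs from compound 2 by 2-(ethoxysulfonyl)ethenyl in place of chloromethyl on an aromatic carbon. The change that bears on it is a 7.4-fold lower number from compound 2 to compound 3 (0.87 log units; beyond the scatter), where an ethenyl-linked group likewise replaced the chloromethyl group; a 10-fold higher number from compound 1 to compound 2 (1.00 log units; beyond the scatter) shows the same gap from the other side. On that basis a step of comparable size in the same direction is expected, a 5.0-fold lower number from compound 2 to compound 4 (0.70 log units; beyond the scatter), placing compound 4 near compound 1 and compound 3. Compound 4 is therefore estimated at 4 nM, with a range of 1.5 nM to 12 nM.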

Compound 4, inhibition constant: 0.3 nM
Compound 4: the middle estimate sits 13-fold (1.12 log units) above what was measured; measured number outside the range, below it.
By their numbers in this assay, from the lowest: compound 4; then compounds 1 and 3 (each within the scatter of the next); then compound 2.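

With the ethenyl link held constant, a 9.0-fold lower number from compound 3 to compound 4 (0.95 log units; beyond the scatter) when ethoxysulfonyl replaces cyano, so the link alone does not set the level at this position and the group carried on it also counts. Compound 1 and compound 3 had marked the lowest level so far, but a 6.7-fold lower number from compound 1 to compound 4 (0.82 log units; beyond the scatter) and a 67-fold lower number from compound 2 to compound 4 (1.83 log units; beyond the scatter) show that this position can go well beyond that level, and that the full replacement of chloromethyl gives a large step. Nothing available here gives a reason for these steps.

On these data alone, it remains open whether the step depends on the ethyl part of the ethoxysulfonyl group or on the sulfonyl part. As far as these compounds go, it is also open whether a carboxylic acid or an amide on the same ethenyl link would fall with compound 4 or with compound 3.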